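Compound 4 and the cytotoxicity of N-substituted analogues

The compounds below may be only part of what the source reports. "The series", "measured", "known", "first", "only" and "open" are said of these compounds alone.

Measured so far in an ADME assay on A549 cells (Homo sapiens) for cytotoxicity, read by resazurin assay, with a stated time of 48 h (a lower number here means that less compound is tolerated, a higher number that more compound is tolerated), are three compounds.
compound 1 `CCNc1ccc(NC(=O)c2cc(Cl)ccc2O)c(Cl)c1` gives 30200 nM
compound 2 `CC1(Nc2ccc(NC(=O)c3cc(Cl)ccc3O)c(Cl)c2)CCCC1` gives 157000 nM
compound 3 `COc1ccc(CNc2ccc(NC(=O)c3cc(Cl)ccc3O)c(Cl)c2)cc1` gives 80700 nM

Compound 3, at 80700 nM in this assay, stands in the upper part of this small set. Its number lies within the scatter of that of compound 2 and beyond the scatter from that of compound 1.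

Compound 4 `O=C(Nc1ccc(NCc2cnccc2Cl)cc1Cl)c1cc(Cl)ccc1O` differs from compound 3 in one place, 4-chloropyridin-3-yl in place of 4-methoxyphenyl on a saturated chain carbon bound to a nitrogen on an aromatic ring and so 4-chloropyridin-3-yl stands in place of 4-methoxyphenyl on a saturated chain carbon bound to a nitrogen on an aromatic ring.

Within the data shown here, three measured steps concern the group on that same nitrogen. They are a 2.7-fold higher number from compound 1 to compound 3 (0.43 log units; beyond the scatter) and a 5.2-fold higher number from compound 1 to compound 2 (0.72 log units; beyond the scatter) and a 1.9-fold lower number from compound 2 to compound 3 (0.29 log units; within the scatter) and none of them is large. None exchanges one aromatic ring for another, and the data hold no direct measure of such a change.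

The expectation is a small one, a 1.3-fold lower number from compound 3 to compound 4 (0.11 log units; within the scatter) with only a slight lean towards a lower number and nothing beyond the scatter. The estimated value for compound 4 is 62000 nM within an expected range of 25000 nM to 150000 nM in this assay once it is measured.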

Compound 4, half-maximal cytotoxic concentration: 126000 nM
Estimate against measurement, compound 4: 2.0-fold (0.31 log units) below; the measured number falls inside the stated range.
By their numbers in this assay, from the lowest: compound 1; then compounds 3, 4 and 2 (each within the scatter of the next).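

In this assay, the exchange of one aromatic ring for another on this saturated chain carbon now has a direct measure, and it stays within the scatter (a 1.6-fold higher number from compound 3 to compound 4 (0.19 log units; within the scatter)). The (4-chloropyridin-3-yl)methyl group of compound 4 also cannot be told apart from the 1-methylcyclopentyl group of compound 2 (a 1.2-fold lower number from compound 2 to compound 4 (0.10 log units; within the scatter)), whereas the step from the ethyl group lies beyond the scatter (a 4.2-fold higher number from compound 1 to compound 4 (0.62 log units; beyond the scatter)), so among these four compounds only compound 1 stands apart, while compounds 2, 3 and 4 carry three different groups on that nitrogen without a separation that can be read. Nothing measured here accounts for this result.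

On these data alone, what stays open is whether the ring nitrogen or the chlorine of the 4-chloropyridin-3-yl group matters on its own, since the two enter together in this one step, and a 4-chlorophenyl or a pyridin-3-yl group on the same chain carbon would separate them. As far as these compounds go, it is also open whether the grouping of compounds 2, 3 and 4 would hold for a group of another kind on that nitrogen, such as a chain ending in a carboxylic acid or an amine.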